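Adding a fluoro group: what trypsin inhibition to expect

A few compounds are considered here, and "the series" means these few. Any claim that something is new, unique, unknown or untested is made for them only; others in the source may bear on it.

Compound 1 `Nc1noc2ccc(-n3nc(C(F)(F)F)cc3C(=O)Cc3ccc(-c4ccccc4S(N)(=O)=O)cc3F)cc12` gives > 20000 nM in an assay on isolated protein for inhibition of Trypsin (Homo sapiens) (a higher number here means a weaker inhibitor, a lower number a stronger inhibitor), a limit of the assay rather than a number.
Compound 2 `COc1ccc(-n2nc(C(F)(F)F)cc2C(=O)Cc2ccc(-c3ccccc3S(N)(=O)=O)cc2)cc1` gives > 2500 nM in this assay, again a limit of the assay.
Compound 3 `COc1ccc(-n2nc(C(F)(F)F)cc2C(=O)Cc2ccc(-c3ccccc3CN3CC[C@H](O)C3)cc2)cc1` gives > 4200 nM in this assay, also a limit of the assay.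

Compound 2 thus stands only at a limit, and no numbered value exists among the measured compounds. Among the measured compounds shown here, the one step between them, a step that the two limits leave unreadable from compound 2 to compound 3, cannot be read, both ends being limits. Compound 4 `COc1ccc(-n2nc(C(F)(F)F)cc2C(=O)Cc2ccc(-c3ccccc3S(N)(=O)=O)cc2F)cc1` differs from compound 2 by fluoro in place of hydrogen on an aromatic carbon. For the measured compounds named here, no measured step bears directly on this change. Compound 1, which also carries this fluoro, sits at the limit (the limit of > 20000 nM in this assay, at which 1 of the 3 values shown sits), and compound 2 sits at the limit (the limit of > 2500 nM in this assay, at which 1 of the 3 values shown sits), so nothing points to a change beyond the scatter. Weak inhibition in this assay is expected for compound 4, with an estimated 10000 nM (range 2000 nM to 50000 nM). The expected step that the limit leaves unreadable from compound 2 to compound 4 is estimated to be none beyond the scatter.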

Compound 4, inhibition constant: > 6000 nM
Compound 4: a limit, no number; the forecaster's own chance of this, stated with the estimate: 85%; the middle value lies beyond the limit too.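

In this assay compound 4 gives > 6000 nM, again a limit of the assay. Its steps from compound 2 and from compound 1 cannot be read, both ends being limits. The compounds shown leave open what the fluoro in place of hydrogen does to trypsin inhibition.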